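Bromine on the fused ring: a second test

A few compounds are considered here, and "the series" means these few. Any claim that something is new, unique, unknown or untested is made for them only; others in the source may bear on it.

Compound 1 `O=C1N=C(N2N=C(c3ccccc3)CC2c2ccccc2O)S/C1=C1/C(=O)Nc2ccccc21`: 4730 nM
Compound 2 `O=C1N=C(N2N=C(c3ccccc3)CC2c2ccccc2O)S/C1=C1/C(=O)Nc2ccc(Br)cc21`: 670 nM
Compound 3 `COc1ccc(C2=NN(C3=NC(=O)/C(=C4\C(=O)Nc5ccccc54)S3)C(c3ccc(OC)cc3)C2)cc1`: 91600 nM

Of the compounds shown here, three have been measured in a functional assay on cells (Cancer cell lines, Homo sapiens) for cytotoxicity, read by sulforhodamine B assay, with a stated time of 48 h; a higher number here means a weaker inhibitor of growth, a lower number a stronger inhibitor of growth. Compound 1 gives 4730 nM in this assay, and compound 2 gives 670 nM. The two differ in one place, (bromo in place of hydrogen on an aromatic carbon), and the step is a 7.1-fold lower number from compound 1 to compound 2 (0.85 log units; beyond the scatter).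

Compound 3 carries a different core; in this assay compound 3 gives 91600 nM, the highest of the three numbers. How the core of compound 3 differs from the core of compound 1 is not broken down here.

Compound 4 `COc1ccc(C2=NN(C3=NC(=O)/C(=C4\C(=O)Nc5ccc(Br)cc54)S3)C(c3ccc(OC)cc3)C2)cc1` has not yet been measured in this assay. It differs from compound 3 by bromo in place of hydrogen on an aromatic carbon, and the place is described in the same words as for the pair of compound 1 and compound 2, so it is the same change seen once more, now on the weaker core. Within the data shown here, whether the bromo gives the same gain on this core as it did once is the open question; the only guide is the single step from compound 1 to compound 2.

On that basis the step from compound 3 to compound 4 is expected to be a 6.1-fold lower number from compound 3 to compound 4 (0.79 log units; beyond the scatter), somewhat smaller than a 7.1-fold lower number from compound 1 to compound 2 (0.85 log units; beyond the scatter) to allow for the change of core. Compound 4 is therefore estimated at 15000 nM in this assay, with a plausible range from 5000 nM to 50000 nM.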

Compound 4, concentration for total growth inhibition: 430 nM
For compound 4 the middle estimate is 35-fold (1.54 log units) above the measured one; measured number outside the range, below it.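

In this assay, bromo in place of hydrogen on an aromatic carbon again gives a step in the same direction on the second core, and this step is large: a 210-fold lower number from compound 3 to compound 4 (2.33 log units; beyond the scatter). The direction of the change therefore carried from one core to the other, but its size did not: the same change on two cores in this assay, a 7.1-fold lower number (0.85 log units; beyond the scatter) from compound 1 to compound 2 and a 210-fold lower number (2.33 log units; beyond the scatter) from compound 3 to compound 4, 30-fold (1.48 log units) apart, beyond the scatter of two such steps

This shows that, in these two pairs, the size of the gain from the bromo depended on the core that carried it, yet two pairs give no rule for a third core and do not reveal which part of the core is responsible for the difference.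

The compounds shown leave open whether chloro or fluoro on the same aromatic carbon would give steps like those of the bromo, and whether a nitrile or an amine at that place would lower the number at all. They also leave open how large the bromo step would be on any core other than these two, so the contrast between the two steps remains a single comparison.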